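The source may hold more compounds than are shown below. What is called first, only, known or untested is meant among the compounds shown, and "the series" means these compounds.

Measured so far:
compound 1 `CSC(=O)N1CCC(Oc2ncnc3c2CCN3c2ccc(S(C)(=O)=O)cc2F)CC1` — 251 nM
compound 2 `CC(C)OC(=O)N1CCC(Oc2ncnc3c2CCN3c2ccc(C#N)cn2)CC1` — 794 nM

In a functional assay on CHO-K1 cells for agonist activity at Glucose-dependent insulinotropic receptor (Homo sapiens), read by a luciferase reporter, with a stated time of 5 h (on this read-out lower numbers stand for an effect already at smaller amounts and higher numbers for an effect only at larger amounts of compound), compound 2 has the highest number of the two, and compound 1 gives 251 nM, a difference beyond the usual scatter. Compound 3 `CSc1ccc(N2CCc3c(OC4CCN(C(=O)OC(C)C)CC4)ncnc32)cc1F` is not yet measured. It differs from compound 2 by a group of 9 heavy atoms (7 carbon, 1 fluorine, 1 sulfur; one six-membered aromatic ring of carbon only) in place of a group of 8 heavy atoms (6 carbon, 2 nitrogen; one six-membered aromatic ring with 1 hetero atom), on a nitrogen on an aromatic ring in a ring. Compound 1, which also carries a fluorine-bearing carbon ring on that nitrogen, gives 251 nM, so a change toward a lower number is expected. The expected step of a 2.0-fold lower number from compound 2 to compound 3 (0.30 log units; within the scatter) is modest and may stay near the scatter. Compound 3 is expected at 400 nM, within a range from 150 nM to 1200 nM.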

Compound 3, half-maximal effective concentration: 398 nM
Estimate against measurement, compound 3: 1.0-fold (0.00 log units) above; measured number inside the range.
By their numbers in this assay, from the lowest: compounds 1, 3 and 2 (each within the scatter of the next, the first and the last beyond it).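

In this assay, putting a carbon-only aromatic ring carrying fluorine and sulfur in place of 5-cyanopyridin-2-yl, on the nitrogen of the five-membered ring, gives a 2.0-fold lower number from compound 2 to compound 3 (0.30 log units; within the scatter). This first one-place comparison therefore cannot tell the two groups apart, and the ring hetero atom and nitrile are not required for a response of this size. Nothing measured here explains the result.

The compounds shown leave open what the fluorine and the sulfur group each contribute, since both arrive together. An amine or a carboxylic acid on this ring could show how far this position responds to other groups.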